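This account rests on a few compounds, and the source may have more. Where it says the series, first, only, none or still open, it means among the compounds named here.

Measured so far:
compound 1 `O=C1NCCN1CC#CCn1ccnc1`; in a functional assay on the whole organism for antagonist activity, with Mus musculus as the target (on this read-out higher numbers stand for an effect only at larger amounts of compound and lower numbers for an effect already at smaller amounts), compound 1 gives > 100 mg/kg, which is a limit of the assay.
compound 2 `Cc1cncn1CC#CCN1CCNC1=O`; in this assay compound 2 gives > 100 mg/kg, again a limit.
compound 3 `Cn1ccn(CC#CCn2ccnc2)c1=O`; in this assay compound 3 gives > 100 mg/kg, again a limit.

Compound 2 arises from compound 1 by methyl in place of hydrogen on an aromatic carbon. The step that the two limits leave unreadable from compound 1 to compound 2 cannot be read because the limit of > 100 mg/kg in this assay, at which 3 of the 3 values shown sit, is where both values sit. How the core of compound 1 differs from the core of compound 3 is not broken down here. Compound 4 `Cc1cncn1CC#CCn1ccn(C)c1=O`, not yet measured, arises from compound 3 by methyl in place of hydrogen on an aromatic carbon, the same change at the same place. In this assay compound 4 is therefore expected to give about 150 mg/kg, estimated between 50 mg/kg and 500 mg/kg. The expected step that the limit leaves unreadable from compound 3 to compound 4 rests on the fact that the limit of > 100 mg/kg in this assay, at which 3 of the 3 values shown sit, is where every measured value sits, and compound 4 is expected most likely to return only a limit as well.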

Compound 4, dose for half-maximal effect: > 100 mg/kg
Compound 4 gave a limit, no number; the forecaster's own chance of this, stated with the estimate: 85%; the middle value does not contradict the limit.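

Compound 4, like compound 3, returns only a limit in this assay, so no step between the two can be read: the limit of > 100 mg/kg in this assay, at which 4 of the 4 values shown sit.

The compounds shown leave open whether methyl in place of hydrogen changes the effective dose at all, and at what dose any of them would act.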